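The source may report more compounds than this note shows. Statements on the series, on what has been measured and on what is new or still open speak of the compounds shown alone.

Measured compounds in an assay on CHO cells for inhibition of bone morphogenetic protein 1 (Homo sapiens), read by fluorescence; on this read-out lower numbers stand for stronger inhibition and higher numbers for weaker inhibition:
- compound 1 `CNC(=O)c1noc([C@H](CCCC2CCCCC2)CC(=O)NO)n1`: 28 nM
- compound 2 `CN(Cc1ccccn1)C(=O)c1noc([C@H](CCCC2CCCCC2)CC(=O)NO)n1`: 40 nM
- compound 3 `NC(=O)c1coc([C@H](CCCC2CCCCC2)CC(=O)NO)n1`: 73 nM

Compound 3 gives the highest number of the three. Its gap to compound 2 is within the scatter; its gap to compound 1 is beyond the scatter, so compound 3 is distinguishable only from compound 1. Among the compounds with values here, the single one-place step in the set, a 1.4-fold higher number from compound 1 to compound 2 (0.15 log units; within the scatter), concerns the amide nitrogen and lies within the scatter.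

Compound 4 `Cc1oc([C@H](CCCC2CCCCC2)CC(=O)NO)nc1C(N)=O` differs from compound 3 by methyl in place of hydrogen on an aromatic carbon; the place is on an aromatic carbon of a five-membered aromatic ring with 1 nitrogen and 1 oxygen, next to the ring oxygen and next to the ring atom that bears a carbamoyl group. Within the data shown here, no measured step touches this ring carbon, and the only measured step, which concerns a different site, was within the scatter. No basis therefore exists for expecting a shift beyond the scatter in this assay in either direction, and the range is kept wide to reflect the absence of a comparable step.

The expected step is a 1.0-fold lower number from compound 3 to compound 4 (0.02 log units; within the scatter), within the scatter. Compound 4 is estimated at 70 nM, between 30 nM and 170 nM.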

Compound 4, half-maximal inhibitory concentration: 17 nM
Estimate against measurement, compound 4: 4.1-fold (0.61 log units) above; measured number below the stated range.
By their numbers in this assay, from the lowest: compounds 4, 1, 2 and 3 (each within the scatter of the next, the first and the last beyond it).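

In this assay, the aromatic carbon next to the ring oxygen and next to the ring atom that bears a carbamoyl group proves sensitive to a very small change, as methyl in place of hydrogen gives a clear shift (a 4.3-fold lower number from compound 3 to compound 4 (0.63 log units; beyond the scatter)). Within the data shown here, this is the first one-place change to go beyond the scatter; the earlier step at the amide nitrogen (a 1.4-fold higher number from compound 1 to compound 2 (0.15 log units; within the scatter)) stayed within it, although each site rests on a single step and on a different core. No measurement available here explains why this methyl lowers the number.

From the compounds shown here alone, it remains open whether the shift is particular to methyl or would also appear with ethyl, chlorine or trifluoromethyl on the same ring carbon, and thus whether the size of the group at this place matters. Going by these compounds, it is also open whether the methyl step holds when the carbamoyl group on the neighbouring ring atom is replaced by a methylamide or a carboxylic acid, so the step cannot yet be treated as independent of that group.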